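Acetylating the Amino Group of Compound 3

The compounds below may be only part of what the source reports. "The series", "measured", "known", "first", "only" and "open" are said of these compounds alone.

Compound 3 `Nc1cccc2c(-c3cccc(NC(=O)Nc4cc(C(F)(F)F)cc(C(F)(F)F)c4)c3)ccnc12` gives the lowest number of the three measured compounds in a functional assay on SK-MEL-2 cells (Homo sapiens) for antiproliferative activity, read by sulforhodamine B assay, with a stated time of 48 h (a lower number here means a stronger inhibitor, a higher number a weaker inhibitor), at 1400 nM. Among the compounds with values here, compound 2 `CC(=O)Nc1cccc2c(-c3cccc(NC(=O)c4ccc(Cl)c(C(F)(F)F)c4)c3)ccnc12` gives 3400 nM, and compound 1 `COc1ccc(C(=O)Nc2cccc(-c3ccnc4c(NC(C)=O)cccc34)c2)cc1OC` gives 9400 nM; the one measured step, a 2.8-fold lower number from compound 1 to compound 2 (0.44 log units; beyond the scatter), concerns a different part of the structure. Compound 4 `CC(=O)Nc1cccc2c(-c3cccc(NC(=O)Nc4cc(C(F)(F)F)cc(C(F)(F)F)c4)c3)ccnc12` differs from compound 3 by acetyl in place of hydrogen on a nitrogen on an aromatic ring, that is, amino to acetamido. Within the data shown here, no measured pair isolates this change: compounds 1 and 2 carry the acetamido group but also differ from compound 3 elsewhere, so their values offer no clean guide. Compound 4 is therefore expected to show only a small step, a 1.4-fold higher number from compound 3 to compound 4 (0.15 log units; within the scatter), near the scatter. Compound 4 is estimated at 2000 nM, in the range 600 nM to 7000 nM.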

Compound 4, half-maximal inhibitory concentration: 14400 nM
Compound 4: the middle estimate sits 7.2-fold (0.86 log units) below what was measured; the measured number lies above the stated range.
By their numbers in this assay, from the lowest: compound 3; then compound 2; then compounds 1 and 4 (each within the scatter of the next).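

Within the data shown here, on a nitrogen on an aromatic ring, amino and acetamido are not interchangeable in this assay: the change gives a 10-fold higher number from compound 3 to compound 4 (1.01 log units; beyond the scatter), the first clean reading at this position. Compounds 1 and 2 both carry acetamido and differ from compound 3 elsewhere, so they could not show this. Nothing measured here explains the size of the step. The compounds shown leave open how a methyl or a methanesulfonyl group on the same nitrogen would compare with acetyl. Whether the step recurs with the other parts of compounds 1 and 2 also stays open, since neither has an amino partner among these compounds.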